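Swapping the aryl group on a shared core

The source may hold more compounds than are shown below. What is called first, only, known or untested is meant among the compounds shown, and "the series" means these compounds.

Three close analogues share one core. Compound 1 `CCCCN(CC)c1cc(C)nc2c1NC(=O)CN2c1ccc(C)cc1Cl` was entered into an assay on HEK-293T cells for displacement of a labelled ligand from corticotropin-releasing factor receptor 2 (Homo sapiens), read by scintillation counting, with a stated time of 2 h, tested at 1 uM (on this read-out higher numbers stand for more inhibition at the one concentration tested (going by the name of the read-out) and lower numbers for less inhibition), yet for compound 1 the entry reads "not determined" (no result reported). Compound 3 `CCCCN(CC)c1cc(C)nc2c1NC(=O)CN2c1ccc(Cl)cc1Br` was entered too, and in this assay compound 3 likewise has the entry "not determined" (no result reported). Compound 2 `CCCCN(CC)c1cc(C)nc2c1NC(=O)CN2c1ccc(C)cc1C` is the only one with a figure: in this assay compound 2 gives 6.8%, a small read-out at the single concentration tested. Compound 3 therefore stands without any number in this assay, and one further entry, compound 1, is in the same position. No pair of measured compounds that differ in one place exists among these three, so no step size has been observed.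

Compound 4 `CCCCN(CC)c1cc(C)nc2c1NC(=O)CN2c1ccc(Br)cc1CC` has not yet been tested. It differs from compound 3 in one place: 4-bromo-2-ethylphenyl in place of 2-bromo-4-chlorophenyl on a nitrogen on an aromatic ring in a ring. Because compound 3 carries only the entry "not determined" (no result reported), the step to compound 4 cannot be given a measured direction. Resting on compound 2 alone, whose read-out in this assay was 6.8%, the author expects compound 4 to show a step of no more than the scatter, with no clear direction. Compound 4 is thus expected to give about 10% in this assay, within a range from -5% to 35%.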

Compound 4, a percentage reported as inhibition, at one concentration (the size of the read-out at that concentration, not a potency): 2.1%
For compound 4 the middle estimate is 7.9 percentage points above the measured one; the measured number falls inside the stated range.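

Where 4-bromo-2-ethylphenyl stands in place of 2,4-dimethylphenyl, on a nitrogen on an aromatic ring in a ring, the series now has its first readable step: there is a number 4.7 percentage points lower from compound 2 to compound 4 (within the scatter) in this assay and this gives the position its first measured pair. Compound 2 and compound 4 therefore cannot be told apart on this read-out, so this exchange of aryl groups leaves the figure at the same low level, while the step from compound 3 to compound 4 cannot be read, as compound 3 has no number. No measurement shown here bears on why the read-out stays at this level.

The compounds shown leave open where compound 1 and compound 3 would fall on this read-out, and so whether any aryl group on the shared core departs from that low level. Also open, going by these compounds, is whether an amine or a carboxylic acid on this phenyl ring, or a longer chain in place of the ethyl group, would move the figure beyond the scatter, and a read-out at one concentration gives no potency for any of them.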